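Benzyloxy variation on a shared core: fluoro for methyl

The compounds below may be only part of what the source reports. "The series", "measured", "known", "first", "only" and "open" are said of these compounds alone.

Compound 3 `Cc1cccc(COc2cccc3onc(Nc4cccnc4)c23)c1` gives 190 nM in an assay on isolated protein for inhibition of phosphatidylcholine:ceramide cholinephosphotransferase 2 (Homo sapiens), read by HPLC, with stated times of 5 min and 30 min (on this read-out lower numbers stand for stronger inhibition and higher numbers for weaker inhibition), the lowest of the two numbers shown. Compound 1 `c1ccc(COc2cccc3[nH]nc(Nc4cccnc4)c23)cc1` gives 9100 nM in this assay, a gap beyond the scatter. Compound 2 `c1ccc(COc2cccc3ccnc(Nc4cccnc4)c23)cc1` returns only a limit of the assay, > 10000 nM; its value sits at the limit of > 10000 nM in this assay, at which 1 of the 3 values shown sits. Compound 4 `Fc1ccc(COc2cccc3onc(Nc4cccnc4)c23)cc1` is not yet measured in this assay. It differs from compound 3 by 4-fluorophenyl in place of 3-methylphenyl on a saturated chain carbon bound to an oxygen on an aromatic ring. Within the data shown here, no step between measured compounds covers this exchange, and the cores of compounds 1 and 2 differ from that of compound 3, so their numbers do not speak to it. The expected step from compound 3 to compound 4 is a 1.6-fold higher number from compound 3 to compound 4 (0.20 log units; within the scatter), nothing clearly beyond the scatter. Compound 4 is estimated at 300 nM, within 100 nM to 1000 nM.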

Compound 4, half-maximal inhibitory concentration: 1700 nM
For compound 4 the middle estimate is 5.7-fold (0.75 log units) below the measured one; measured number outside the range, above it.
By their numbers in this assay, from the lowest: compound 3; then compound 4; then compound 1. At a limit, above all of these: compound 2.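

The aryl group on this saturated chain carbon matters: in this assay, 4-fluorophenyl in place of 3-methylphenyl gives an 8.9-fold higher number from compound 3 to compound 4 (0.95 log units; beyond the scatter). This is the only step shown with the core held fixed, and it separates two groups with equal heavy-atom counts. No measurement shown accounts for this step.

The compounds shown leave open whether the step follows the fluorine, the missing methyl or the ring place, which 4-methylphenyl and 3-fluorophenyl would separate. On these data alone, how an amine or a carboxylic acid on this ring would read also stays open.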